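A few compounds are considered here, and "the series" means these few. Any claim that something is new, unique, unknown or untested is made for them only; others in the source may bear on it.

Measured in a functional assay on cells (Melanoma cell, Homo sapiens) for inhibition; on this read-out lower numbers stand for stronger inhibition of growth and higher numbers for weaker inhibition of growth:
- compound 1 `Cc1cn2c(/C=N/Nc3ccccn3)c(-c3ccc(Cl)c([N+](=O)[O-])c3)nc2s1`: 38000 nM
- compound 2 `N=C(N)N/N=C/c1c(-c2cc(Cl)sc2Cl)nc2n1CCS2`: 20400 nM
- compound 3 `N=C(N)N/N=C/c1c(-c2cccs2)nc2sccn12`: 28800 nM

The three values lie within the usual scatter of one another, so compound 2, at 20400 nM, does not stand apart from the other two. Compound 4 `N=C(N)N/N=C/c1c(-c2cccs2)nc2n1CCS2`, not yet measured, has thiophen-2-yl in place of 2,5-dichlorothiophen-3-yl on an aromatic carbon. Among the measured compounds shown here, no pair of measured compounds differs in only one place, so the data offer no direct guide to the size of this step. The closest evidence is compound 3, which carries thiophen-2-yl on the core of its own and gives 28800 nM, within the scatter of compound 2. In this assay, therefore, no step beyond the scatter is expected, in either direction. The estimated change is a 1.3-fold higher number from compound 2 to compound 4 (0.12 log units; within the scatter). For compound 4 the expected value is 27000 nM, with an estimated range of 13000 nM to 55000 nM.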

Compound 4, concentration for total growth inhibition: 38000 nM
The estimate for compound 4 lay 1.4-fold (0.15 log units) below the measured number; the measured number falls inside the stated range.
By their numbers in this assay, from the lowest: compounds 2, 3, 1 and 4 (each within the scatter of the next).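

Compound 2 and compound 4 are the only pair shown that differs in one place, so the aromatic carbon next to the ring nitrogen can now be read directly. In this assay, thiophen-2-yl in place of 2,5-dichlorothiophen-3-yl gives a 1.9-fold higher number from compound 2 to compound 4 (0.27 log units; within the scatter), so this exchange of one thiophene group for the other, which leaves out both chlorine atoms, makes no change beyond the scatter at this position. No other measurement bears on why this is so.

On these data alone, whether a group of another kind at this carbon, such as an unsubstituted phenyl ring or a primary amine, would move the number beyond the scatter remains open. Also open, as far as these compounds go, is whether 2,5-dichlorothiophen-3-yl on the core of compound 3 would give a similar step.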